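The source may report more compounds than this note shows. Statements on the series, on what has been measured and on what is new or still open speak of the compounds shown alone.

Measured compounds:
- Compound 1 `COc1ccc([C@H]2CC(=O)N(c3ccccc3C#N)C2)cc1OC1CCCC1`. In a functional assay on HEK293 cells (Homo sapiens) for cytotoxicity (a higher number here means that more compound is tolerated, a lower number that less compound is tolerated), compound 1 gives > 10000 nM, a limit of the assay.
- Compound 2 `COc1ccc([C@H]2CC(=O)N(c3ccccc3C(F)(F)F)C2)cc1OC1CCCC1`. In this assay compound 2 gives > 10000 nM, a limit of the assay.
- Compound 3 `COc1ccc([C@H]2CC(=O)N(c3cccc(S(C)(=O)=O)c3)C2)cc1OC1CCCC1`. In this assay compound 3 gives > 10000 nM, a limit of the assay.

Going by the values given here, compound 3 therefore stands at the same limit as the other two; all three values shown sit there (the limit of > 10000 nM in this assay, at which 3 of the 3 values shown sit), so no compound can be ranked against another in this assay.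

The next compound is compound 4 `COc1ccc([C@H]2CC(=O)N(c3cccc(NS(=O)(=O)c4ccccc4C)c3)C2)cc1OC1CCCC1`. Its change from compound 3 is ((2-methylphenyl)sulfonyl)amino in place of methylsulfonyl on an aromatic carbon.

Which measured steps bear on it: the steps that change the group on the amide-type nitrogen in the ring, a step that the two limits leave unreadable from compound 1 to compound 3 and a step that the two limits leave unreadable from compound 2 to compound 3, and the step that the two limits leave unreadable from compound 1 to compound 2. None of them yields a readable size, because every value involved is a limit (the limit of > 10000 nM in this assay, at which 3 of the 3 values shown sit). For this assay no step beyond the scatter is therefore expected from the change to ((2-methylphenyl)sulfonyl)amino.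

Compound 4 is expected to give 10000 nM, within 5000 nM to 30000 nM. The expected step of a number no higher from compound 3 to compound 4 (the limit leaves the size open) is an estimate only, most likely to be reported again as a limit.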

Compound 4, half-maximal cytotoxic concentration: > 10000 nM
Compound 4 ended at the assay's limit (the forecaster's own chance of this, stated with the estimate: 80%); the middle value sits exactly at the limit.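

In this assay compound 4 gives > 10000 nM, a limit of the assay. No step from compound 3 to compound 4 can be read, and the series stays unranked: the limit of > 10000 nM in this assay, at which 4 of the 4 values shown sit.

On these data alone, the half-maximal cytotoxic concentration of compound 1, compound 2, compound 3 and compound 4 remains open, as does any effect of the changed groups on it.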